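Cytotoxicity limits across three aryl variants of a shared core

The source may hold more compounds than are shown below. What is called first, only, known or untested is meant among the compounds shown, and "the series" means these compounds.

Compound 1 `COc1ccc([C@@H]2CC(=O)C[C@H](c3ccco3)C23C(=O)OC(C)(C)OC3=O)cc1`: in an ADME assay on MT2 cells (Homo sapiens) for cytotoxicity (on this read-out lower numbers stand for higher toxicity in this test and higher numbers for lower toxicity in this test), compound 1 gives only a limit of the assay, > 111000 nM.
Compound 2 `CC1(C)OC(=O)C2(C(=O)O1)[C@@H](c1ccco1)CC(=O)C[C@H]2c1ccccc1Cl`: in this assay compound 2 gives only a limit, > 111000 nM.
Compound 3 `COc1ccc([C@@H]2CC(=O)C[C@H](c3ccco3)C23C(=O)OC(C)(C)OC3=O)cc1OC`: in this assay compound 3 gives only a limit, > 111000 nM.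

Compound 3 therefore stands at the same limit as the others, which the limit of > 111000 nM in this assay, at which 3 of the 3 values shown sit, records for all three. The steps a step that the two limits leave unreadable from compound 1 to compound 3, a step that the two limits leave unreadable from compound 1 to compound 2 and a step that the two limits leave unreadable from compound 2 to compound 3 are all unreadable, since both ends are limits. Compound 4 `COc1ccc([C@@H]2CC(=O)C[C@H](c3ccco3)C23C(=O)OC(C)(C)OC3=O)c(C)c1` differs from compound 3 by 4-methoxy-2-methylphenyl in place of 3,4-dimethoxyphenyl on a saturated ring carbon. The related steps give no readable size, so no shift beyond the scatter in this assay is expected; the step of a number no higher from compound 3 to compound 4 (the limit leaves the size open) is an estimate of no change. Compound 4 is expected at 111000 nM, in the range 50000 nM to 250000 nM, most likely again as a limit.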

Compound 4, half-maximal cytotoxic concentration: > 111000 nM
Compound 4 ended at the assay's limit; the forecaster's own chance of this, stated with the estimate: 85%; the middle value lies on the limit itself.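

No step between compound 1, compound 2, compound 3 and compound 4 can be read, since each value is a limit of the assay and not a number: the limit of > 111000 nM in this assay, at which 4 of the 4 values shown sit.

The compounds shown leave open whether any of these aryl changes on the shared core alters cytotoxicity.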